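The source may report more compounds than this note shows. Statements on the series, on what has been measured and on what is new or still open speak of the compounds shown alone.

Compound 1, `Fc1ccc(-c2cn(C3CN4CCC3CC4)nn2)cc1`, stands with the lowest of the two numbers measured in an assay on HEK293 cells for displacement of a labelled ligand from Neuronal acetylcholine receptor; alpha4/beta2 (Homo sapiens), read by scintillation counting, with a stated time of 120 min; a lower number here means a stronger inhibitor, a higher number a weaker inhibitor; compound 1 gives 449 nM in this assay. For the measured compounds named here, its only measured companion is compound 2, `FCCCOc1cccc(-c2cn([C@H]3CN4CCC3CC4)nn2)c1`, which in this assay gives 9010 nM, a much higher number, and the two differ in more than one place, so nothing can be read from that pair about a single change.

Compound 3, `Fc1ccc(-c2cn([C@H]3CN4CCC3CC4)nn2)cc1`, shares every atom and bond with compound 1; the change is the two compounds have the same atoms and bonds; at least one stereo element is drawn with a configuration in one of them and without one in the other: 1 of 3 stereo elements differ; a stereocentre at a saturated ring carbon is drawn without a configuration in compound 1 and R in compound 3. A drawn configuration means that compound 3 is one of the forms contained in compound 1, and compound 2 carries the same drawn configuration on the same saturated ring carbon. Going by the values given here, no single-change step between measured compounds exists to calibrate this, so the expectation rests on the structural relation alone: a modest move, most likely toward a lower number, with a fair chance of no change beyond the scatter.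

Compound 3 is therefore estimated at 300 nM, with a range from 100 nM to 1500 nM, which would be a step of a 1.5-fold lower number from compound 1 to compound 3 (0.18 log units; within the scatter) from compound 1.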

Compound 3, inhibition constant: 10400 nM
Compound 3: middle estimate off by 35-fold (1.54 log units), on the low side; measured number outside the range, above it.
By their numbers in this assay, from the lowest: compound 1; then compounds 2 and 3 (each within the scatter of the next).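

Drawing the saturated ring carbon as R moves the number in this assay sharply upward, with a 23-fold higher number from compound 1 to compound 3 (1.36 log units; beyond the scatter), so this single stereocentre is a place to which the assay responds strongly, something the earlier pair, differing in more than one place, could not show. Since compound 3 is one of the forms contained in compound 1, the R form does not by itself account for the number of compound 1, 449 nM, and if compound 1 holds more than one form, its lower number must come mainly from a form other than R. The two structures share every atom and bond, so the whole step traces to one feature: the fact that one of compounds 1 and 3 is drawn with a defined configuration and the other without, at the place where they differ

Going by these compounds, the make-up of compound 1, and the number its other form would give on its own, stay open. Also open, on these data alone, is whether the configuration at this carbon would matter as much with a nitrile or a methoxy group in place of the fluorine.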